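This account rests on a few compounds, and the source may have more. Where it says the series, first, only, none or still open, it means among the compounds named here.

Notes on the series in an in vivo ADME assay on the whole organism (Cavia porcellus); a higher number here means that the compound lasts longer, a lower number that the compound disappears faster: compound 1 (`CCCCC(NC(=O)c1ccc(C(=N)N)cc1)C(C)(C)C(=O)N1CCC(CC(=O)O)CC1`) gives 1.03 h, compound 2 (`CC(C)(C(=O)N1CCC(CC(=O)O)CC1)C(NC(=O)c1ccc(C(=N)N)cc1)c1ccc2ccccc2c1`) gives 0.85 h and compound 3 (`CC(C)(C(=O)N1CCC(CC(=O)O)CC1)C(NC(=O)c1ccc(C(=N)N)cc1)c1ccc(O)cc1`) gives 1.05 h, so compound 3 stands level with the other two within the scatter. Compound 4 (`CC(C)(C(=O)N1CCC(CC(=O)O)CC1)C(NC(=O)c1ccc(C(=N)N)cc1)c1cccc(O)c1`) carries 3-hydroxyphenyl in place of 4-hydroxyphenyl on a saturated chain carbon bound to an amide-type nitrogen and a saturated chain carbon. Going by the values given here, no measured step makes this exact exchange. The closest evidence is at the same place: a 1.2-fold lower number from compound 1 to compound 2 (0.08 log units; within the scatter), a 1.0-fold higher number from compound 1 to compound 3 (0.01 log units; within the scatter) and a 1.2-fold higher number from compound 2 to compound 3 (0.09 log units; within the scatter), all within the scatter. Therefore no step beyond the scatter is expected in this assay. The expected change is a 1.1-fold lower number from compound 3 to compound 4 (0.02 log units; within the scatter). For compound 4 the estimated half-life is 1 h, with an expected range of 0.7 h to 1.45 h.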

Compound 4, half-life: 1.08 h
The estimate for compound 4 lay 1.1-fold (0.03 log units) below the measured number, within the range that was stated.
By their numbers in this assay, from the lowest: compounds 2, 1, 3 and 4 (each within the scatter of the next).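

In this assay the exchange of 4-hydroxyphenyl for 3-hydroxyphenyl is now a measured step (a 1.0-fold higher number from compound 3 to compound 4 (0.01 log units; within the scatter)), so the two hydroxyphenyl groups stand level at this place. 3-Hydroxyphenyl also stands level with naphthalen-2-yl (a 1.3-fold higher number from compound 2 to compound 4 (0.10 log units; within the scatter)) and with butyl (a 1.0-fold higher number from compound 1 to compound 4 (0.02 log units; within the scatter)), so all four groups shown at this place lie within the scatter of each other. No evidence is available that explains this flat result.

Still open, going by these compounds, is whether an amine or a carboxylic acid at this place would move the half-life beyond the scatter.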